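This account rests on a few compounds, and the source may have more. Where it says the series, first, only, none or still open, it means among the compounds named here.

Measured so far in an assay on cells for agonist activity at vitamin D3 receptor (Homo sapiens), with a stated time of 96 h; a higher number here means that more compound is needed for the effect, a lower number that less compound is needed:

Compound 1 `CCn1c(C(=O)NCCCN(C)C)ccc1C(CC)(CC)c1ccc(OCCC(O)(CC)CC)c(C)c1` gives 5 nM.
Compound 2 `CCn1c(C(=O)NCCN(C)C)ccc1C(CC)(CC)c1ccc(OCCC(O)(CC)CC)c(C)c1` gives 82 nM.
Compound 3 `C#CCCOC(=O)c1ccc(C(CC)(CC)c2ccc(OCCC(O)(CC)CC)c(C)c2)n1CC` gives 6030 nM.

Compound 3 stands highest of the three numbers: the step from its nearest neighbour is a 74-fold higher number from compound 2 to compound 3 (1.87 log units; beyond the scatter), and from the furthest it is a 1200-fold higher number from compound 1 to compound 3 (3.08 log units; beyond the scatter).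

Compound 4 `CCOC(=O)CN(C)C(=O)c1ccc(C(CC)(CC)c2ccc(OCCC(O)(CC)CC)c(C)c2)n1CC` is the next one to be measured. Its change from compound 3 is ((ethoxycarbonyl)methyl)(methyl)amino in place of (but-3-yn-1-yl)oxy on a carbonyl carbon. The two steps that bear on this are the ones leading into compound 3, a 1200-fold higher number from compound 1 to compound 3 (3.08 log units; beyond the scatter) and a 74-fold higher number from compound 2 to compound 3 (1.87 log units; beyond the scatter), both large and both in the direction of a higher number when the substituent on the carbonyl carbon was changed from an amino group to the (but-3-yn-1-yl)oxy group. Compound 4 reverses that type of change, so a lower number is expected, but compound 4 carries no dimethylamino group, and a 16-fold higher number from compound 1 to compound 2 (1.21 log units; beyond the scatter) shows that the placement of that group alone moved the number a good deal. The expected step for compound 4 is therefore a 20-fold lower number from compound 3 to compound 4 (1.30 log units; beyond the scatter), smaller than the full return to compound 1. The estimate for compound 4 in this assay is 300 nM, with a range from 50 nM to 2000 nM.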

Compound 4, half-maximal effective concentration: 520 nM
The estimate for compound 4 lay 1.7-fold (0.24 log units) below the measured number, and the stated range covers the measured number.
By their numbers in this assay, from the lowest: compound 1; then compound 2; then compound 4; then compound 3.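

In this assay, ((ethoxycarbonyl)methyl)(methyl)amino on the carbonyl carbon gives a 12-fold lower number from compound 3 to compound 4 (1.06 log units; beyond the scatter), so a substituent linked through nitrogen lowers the number relative to (but-3-yn-1-yl)oxy even with no dimethylamino group present. That recovery is only partial, with a 6.3-fold higher number from compound 2 to compound 4 (0.80 log units; beyond the scatter) and a 100-fold higher number from compound 1 to compound 4 (2.02 log units; beyond the scatter), so among these compounds the lowest numbers belong to the two that carry a dimethylamino group at the end of an amino chain. No evidence on the cause of these steps is available.

Open, going by these compounds, is whether a carboxylic acid in place of the ethoxycarbonyl group would shift the number for compound 4, and whether the methyl on its nitrogen contributes to the step. Also open, on these data alone, is whether a longer chain ending in dimethylamino would lower the number further than in compound 1.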